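The compounds below may be only part of what the source reports. "The series", "measured", "known", "first", "only" and "open" are said of these compounds alone.

Measured so far:
- compound 1, `C=CC1=C(C(=O)NCCCCC)C(c2ccc(OC)cc2)OC1`: > 100000 nM
- compound 2, `C=CC1=C(C(=O)Nc2ccccc2)C(c2ccc(Cl)c(Cl)c2)OC1`: > 100000 nM
- compound 3, `C=CC1=C(C(=O)Nc2ccccc2OC)C(c2ccc(F)cc2)OC1`: > 100000 nM

In a functional assay on SW480 cells (Homo sapiens) for cytotoxicity, read by MTT assay, with a stated time of 24 h (a higher number here means a weaker inhibitor, a lower number a stronger inhibitor), compound 1 gives > 100000 nM, which is a limit of the assay and not a number. Compound 2 likewise gives only the limit > 100000 nM. Compound 3 also sits at the limit, > 100000 nM. So compound 1 cannot be placed against the other two: all three rest on (the limit of > 100000 nM in this assay, at which 3 of the 3 values shown sit), and no ordering among them can be read from the data. Within the data shown here, no step between measured compounds is available on which to lean.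

Compound 4, `C=CC1=C(C(=O)NC(C)(C)C)C(c2ccc(OC)cc2)OC1`, has not been measured. It differs from compound 1 by tert-butyl in place of pentyl on an amide-type nitrogen. The change keeps the same amide-type nitrogen and the same core, exchanging one alkyl group on that nitrogen for another.

The expected step that the limit leaves unreadable from compound 1 to compound 4 is none beyond the scatter, given that compound 1 sits at the limit > 100000 nM. Compound 4 is estimated at 200000 nM, within the range 50000 nM to 1000000 nM, most likely again reported only as a limit.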

Compound 4, half-maximal inhibitory concentration: > 100000 nM
Compound 4: a limit, no number; the forecaster's own chance of this, stated with the estimate: 85%; the middle value lies beyond the limit too.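

In this assay, compound 1 and compound 4 both give a limit and not a number, so no step between them can be read: the limit of > 100000 nM in this assay, at which 4 of the 4 values shown sit.

The compounds shown leave open whether any change on the shared core gives a readable value.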